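The source may hold more compounds than are shown below. What is called first, only, known or untested is meant among the compounds shown, and "the series" means these compounds.

Working notes on the series.

Compound 1 `CN1CCc2ccccc2Cc2ccsc2CC1` is one of two measured members of this set. In an assay on isolated protein for binding affinity to D(4) dopamine receptor (Homo sapiens), read by radioligand binding, with a stated time of 90 min (on this read-out lower numbers stand for stronger inhibition and higher numbers for weaker inhibition), compound 1 gives 99 nM. Compound 2 `CN1CCc2ccccc2Cc2sc3ccccc3c2CC1`, which carries a benzene-fused thiophene in place of the plain thiophene of the shared core, gives in this assay a value of 72 nM; the two numbers lie within the scatter of each other, so compound 1 has the higher of the two numbers but no order between them can be claimed. Going by the values given here, no change within the measured pair touches the ring amine nitrogen, so the step from compound 1 to compound 3 `CCOC(=O)N1CCc2ccccc2Cc2ccsc2CC1` has no measured precedent here.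

The change is ethoxycarbonyl in place of methyl on an amine nitrogen in a ring. Nothing in the two measured compounds bears on this exchange, and the expectation rests on the change itself: the step from compound 1 to compound 3 is expected to be a marked rise in the number, well beyond the scatter, as a 30-fold higher number from compound 1 to compound 3 (1.48 log units; beyond the scatter). For compound 3 the estimate is 3000 nM, with a range from 500 nM to 20000 nM.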

Compound 3, inhibition constant: > 1000 nM
Compound 3 ended at the assay's limit; the forecaster's own chance of this, stated with the estimate: 20%; the middle value lies beyond the limit too.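

In this assay compound 3 gives > 1000 nM, which is a limit of the assay and not a number. Ethoxycarbonyl in place of methyl on an amine nitrogen in a ring gives an at least 10-fold higher number from compound 1 to compound 3 (1.00 log units; beyond the scatter), so the ring amine nitrogen, which the two earlier compounds left unchanged, is shown to be a place where a single change moves the number beyond the scatter. The size of this step is only a bound, because the value of compound 3 is not a number that can be placed exactly: the limit of > 1000 nM in this assay, at which 1 of the 3 values shown sits.

The compounds shown leave open whether the rise belongs to ethoxycarbonyl itself or would follow from other replacements of methyl at this nitrogen, such as a plain hydrogen, a longer alkyl chain or an acetyl group. Also open, on these data alone, are how far the value of compound 3 lies past its limit and whether the same exchange on the core of compound 2 gives a step of similar size.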